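Series notes: compound 4 in the antagonist assay

A few compounds are considered here, and "the series" means these few. Any claim that something is new, unique, unknown or untested is made for them only; others in the source may bear on it.

Measured so far:
Compound 1 `CCCn1cnc2c(N(C)C)ncnc21` gives 14 mg/kg in a functional assay on the whole organism for antagonist activity, with Rattus norvegicus as the target; a lower number here means that less compound is needed, a higher number that more compound is needed for the effect.
Compound 2 `CC(C)n1cnc2c(N(C)C)ncnc21` gives 11 mg/kg in this assay.
Compound 3 `CCCn1cnc2c(NC3CC3)ncnc21` gives 6 mg/kg in this assay.

Two changes have been made on the shared core. The first, (isopropyl in place of propyl on an aromatic nitrogen), gives a 1.3-fold lower number from compound 1 to compound 2 (0.10 log units; within the scatter), so compound 1 and compound 2 are not distinguishable by this measurement. The second, (cyclopropylamino in place of dimethylamino on an aromatic carbon), is how the core of compound 3 differs from that of compound 1, and gives a 2.3-fold lower number from compound 1 to compound 3 (0.37 log units; beyond the scatter). Compound 3 and compound 2 lie within the scatter of each other; compound 3 does stand beyond the scatter from compound 1.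

Compound 4 `CC(C)n1cnc2c(NC3CC3)ncnc21` has not been measured. It differs from compound 3 by isopropyl in place of propyl on an aromatic nitrogen, which is the same change, at the same place, as that from compound 1 to compound 2. Since that change produced only a 1.3-fold lower number from compound 1 to compound 2 (0.10 log units; within the scatter), the expectation in this assay is a step of about the same small size, a 1.2-fold lower number from compound 3 to compound 4 (0.08 log units; within the scatter). Compound 4 is therefore estimated at 5 mg/kg, with a range from 2.5 mg/kg to 10 mg/kg.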

Compound 4, dose for half-maximal effect: 4 mg/kg
Compound 4: middle estimate off by 1.3-fold (0.10 log units), on the high side; low and high end bracket the measured number.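

In this assay, isopropyl in place of propyl on an aromatic nitrogen gives a 1.5-fold lower number from compound 3 to compound 4 (0.18 log units; within the scatter), and the step reads alike on both cores: the same change on two cores in this assay, a 1.3-fold lower number (0.10 log units; within the scatter) from compound 1 to compound 2 and a 1.5-fold lower number (0.18 log units; within the scatter) from compound 3 to compound 4, 1.2-fold (0.07 log units) apart, within the scatter of two such steps. Cyclopropylamino in place of dimethylamino on an aromatic carbon gives a 2.8-fold lower number from compound 2 to compound 4 (0.44 log units; beyond the scatter), and this step also reads alike on both cores: the same change on two cores in this assay, a 2.3-fold lower number (0.37 log units; beyond the scatter) from compound 1 to compound 3 and a 2.8-fold lower number (0.44 log units; beyond the scatter) from compound 2 to compound 4, 1.2-fold (0.07 log units) apart, within the scatter of two such steps. Across these four compounds, each change therefore carries over from one core to the other with no sign that either depends on the other, but each comparison rests on only two steps, the isopropyl steps lie within the scatter, and nothing here shows that the same would hold on any other core.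

Still open, on these data alone, is whether a longer chain such as butyl, or a ring such as cyclobutyl, on the aromatic nitrogen would fit the same picture. Also open, as far as these compounds go, is whether another amine on the aromatic carbon, such as morpholine or a free amino group, would carry over as cyclopropylamino does.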